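The source may report more compounds than this note shows. Statements on the series, on what has been measured and on what is new or still open speak of the compounds shown alone.

Measured in a functional assay on CHO-K1 cells for antagonist activity at transient receptor potential cation channel subfamily V member 1 (Homo sapiens), read by FLIPR; on this read-out higher numbers stand for weaker inhibition and lower numbers for stronger inhibition:
compound 1 `CC(C(=O)NCc1ccc(C(F)(F)F)nc1Nc1ccccc1)c1ccc(NS(C)(=O)=O)c(F)c1` — 1400 nM
compound 2 `Cc1ccc(Cl)cc1Nc1nc(C(F)(F)F)ccc1CNC(=O)C(C)c1ccc(NS(C)(=O)=O)c(F)c1` — 140 nM
compound 3 `CC(C(=O)NCc1ccc(C(F)(F)F)nc1N(C)c1ccccc1)c1ccc(NS(C)(=O)=O)c(F)c1` — 57.4 nM

Compound 3 holds the lowest number of the three: a 2.4-fold lower number from compound 2 to compound 3 (0.39 log units; beyond the scatter) and a 24-fold lower number from compound 1 to compound 3 (1.39 log units; beyond the scatter). Compound 4 `CC(C(=O)NCc1ccc(C(F)(F)F)nc1N1CC=CCC1)c1ccc(NS(C)(=O)=O)c(F)c1` differs from compound 3 in that (a group of 6 heavy atoms (5 carbon, 1 nitrogen; one six-membered non-aromatic ring with 1 hetero atom) in place of a group of 8 heavy atoms (7 carbon, 1 nitrogen; one six-membered aromatic ring of carbon only), on an aromatic carbon). The nitrogen stays fully substituted as in compound 3, so the hydrogen of compound 1 is not returned and the large step of a 24-fold lower number from compound 1 to compound 3 (1.39 log units; beyond the scatter) is not undone; the aryl change a 2.4-fold lower number from compound 2 to compound 3 (0.39 log units; beyond the scatter) shows that the group on this nitrogen moves the number modestly. For the measured compounds named here, no measured step removes the aromatic ring from this nitrogen, so only a modest rise in this assay is expected, a 2.6-fold higher number from compound 3 to compound 4 (0.42 log units; beyond the scatter). Compound 4 is estimated at 150 nM (range 40 nM to 600 nM).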

Compound 4, half-maximal inhibitory concentration: 12.1 nM
For compound 4 the middle estimate is 12-fold (1.09 log units) above the measured one; measured number below the stated range.
By their numbers in this assay, from the lowest: compound 4; then compound 3; then compound 2; then compound 1.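

In this assay an aromatic ring on this nitrogen is not needed: a six-membered non-aromatic ring that takes in the nitrogen and holds one double bond gives a 4.7-fold lower number from compound 3 to compound 4 (0.68 log units; beyond the scatter). Against the two compounds with a hydrogen on this nitrogen, the same ring gives a 12-fold lower number from compound 2 to compound 4 (1.06 log units; beyond the scatter) and a 120-fold lower number from compound 1 to compound 4 (2.06 log units; beyond the scatter), leaving compound 4 with the lowest number of the four. Nothing at hand explains this gain.

The compounds shown leave open whether the ring double bond counts, which a piperidine or a morpholine on this aromatic carbon would test. A dimethylamino group there would show whether any ring is needed.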